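From Chloro to Propylamino on the Shared Core

A few compounds are considered here, and "the series" means these few. Any claim that something is new, unique, unknown or untested is made for them only; others in the source may bear on it.

Values measured in a functional assay on MOLT-4 cells (Homo sapiens); on this read-out lower numbers stand for stronger inhibition and higher numbers for weaker inhibition:
- Compound 1 `Cn1ncc2c1[C@@H](CO[Si](c1ccccc1)(c1ccccc1)C(C)(C)C)C[C@H]2Cn1cnc2c(O)ncnc21`: 3.2 ug/mL
- Compound 2 `CCOc1ncnc2c1ncn2C[C@@H]1C[C@H](CO)c2ccccc21`: 24 ug/mL
- Compound 3 `OC[C@H]1C[C@@H](Cn2cnc3c(Cl)ncnc32)c2ccccc21`: 24 ug/mL

Compound 3, at 24 ug/mL, stands level with compound 2, and together they hold the highest number of the three. Compound 1, at 3.2 ug/mL, lies lower by more than the scatter, but it differs from compound 3 in more than one place and offers no direct guide here.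

Compound 4 `CCCNc1ncnc2c1ncn2C[C@@H]1C[C@H](CO)c2ccccc21` has not yet been measured in this assay. It carries propylamino in place of chloro on an aromatic carbon. That carbon belongs to a six-membered aromatic ring with 2 nitrogen, part of a fused or bridged system of two rings.

Among the compounds with values here, only one measured step bears on this change: no change at the digits printed from compound 2 to compound 3 (within the scatter), with chloro in place of ethoxy on an aromatic carbon. Within the data shown here, that single step is small, but no amino-bearing compound has been measured, so the evidence is thin. No shift beyond the scatter is therefore expected, though the range must stay wide.

The expected step is a 1.2-fold lower number from compound 3 to compound 4 (0.08 log units; within the scatter). For compound 4 the estimate is 20 ug/mL, with an expected range from 8 ug/mL to 50 ug/mL.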

Compound 4, half-maximal inhibitory concentration: 24 ug/mL
Beside the measured number, compound 4's estimate is 1.2-fold (0.08 log units) below it; measured number inside the range.
By their numbers in this assay, from the lowest: compound 1; then compounds 2, 3 and 4 (each within the scatter of the next).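

In this assay, the earlier compounds had shown only chloro and ethoxy on this aromatic carbon. Propylamino, with 4 heavy atoms and 1 hydrogen-bond donor where chloro has 1 heavy atom and no donor, gives no change at the digits printed from compound 3 to compound 4 (within the scatter), and against ethoxy the result is likewise no change at the digits printed from compound 2 to compound 4 (within the scatter), so this read-out does not separate the three groups at this position. Nothing in the data at hand accounts for why these groups read alike.

Going by these compounds, it remains open whether the same level would hold for a group of another kind on this carbon, such as dimethylamino, a longer chain such as hexylamino, or a carboxylic acid. Compound 1 differs from these compounds in more than one place, so its lower number cannot be assigned to this position or to any single change.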